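The compounds below may be only part of what the source reports. "The series", "measured", "known", "first", "only" and "open" are said of these compounds alone.

Compound 1 `Cc1nc(-c2ccccc2)c(C(=O)N2CCN(c3cccc(C#N)c3)CC2)o1` in a functional assay on HL-60 cells (Homo sapiens) for inhibition, read by MTT assay, with a stated time of 72 h; a higher number here means a weaker inhibitor, a lower number a stronger inhibitor: 39.6 nM
Compound 2 `Cc1ccc(N2CCN(C(=O)c3oc(C)nc3-c3ccccc3)CC2)c(C)c1`: 101 nM
Compound 3 `Cc1nc(-c2ccccc2)c(C(=O)N2CCN(c3ccc(C)c(C)c3)CC2)o1`: 43 nM

Compound 3 stands second highest of the three numbers. Its nearest neighbour is compound 1 (a 1.1-fold higher number from compound 1 to compound 3 (0.04 log units; within the scatter)), its furthest compound 2 (a 2.3-fold lower number from compound 2 to compound 3 (0.37 log units; beyond the scatter)). Compound 4 `Cc1nc(-c2ccccc2)c(C(=O)N2CCN(c3cccc(F)c3)CC2)o1` differs from compound 3 in one place: 3-fluorophenyl in place of 3,4-dimethylphenyl on an amine nitrogen in a ring. Among the measured compounds shown here, two measured steps bear on this. The change from compound 1 to compound 3 left the number essentially unchanged, while the change from compound 2 to compound 3 was modest; the step from compound 1 to compound 2 (a 2.6-fold higher number from compound 1 to compound 2 (0.41 log units; beyond the scatter)) sets the spread seen so far. Because a 1.1-fold higher number from compound 1 to compound 3 (0.04 log units; within the scatter) was within the scatter, compound 4 is expected to land close to compound 3, with a 1.0-fold higher number from compound 3 to compound 4 (0.02 log units; within the scatter). Compound 4 is therefore estimated at 45 nM, with a range from 20 nM to 110 nM.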

Compound 4, half-maximal inhibitory concentration: 45 nM
Beside the measured number, compound 4's estimate shows no gap at the digits printed; measured number inside the range.
By their numbers in this assay, from the lowest: compounds 1, 3 and 4 (each within the scatter of the next); then compound 2.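

In this assay, 3-fluorophenyl on the amine nitrogen in a ring matches 3,4-dimethylphenyl within the scatter (a 1.0-fold higher number from compound 3 to compound 4 (0.02 log units; within the scatter)), and fluoro in place of cyano on an aromatic carbon also stays within it (a 1.1-fold higher number from compound 1 to compound 4 (0.06 log units; within the scatter)). Against 2,4-dimethylphenyl, the same 3-fluorophenyl group gives a modest step beyond the scatter (a 2.2-fold lower number from compound 2 to compound 4 (0.35 log units; beyond the scatter)), so compound 2 remains the only one of the four set apart. No measurement shown accounts for these steps. On these data alone, whether a carboxylic acid or an amine on this phenyl ring would leave the number in the same range stays open.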